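Methoxy for chloro on the aryl ring of compound 1

The compounds below may be only part of what the source reports. "The series", "measured", "known", "first", "only" and "open" are said of these compounds alone.

Measured so far:
compound 1, `C=C(Br)C(=O)Nc1cccc(-c2cn3nc(-c4ccc(Cl)cc4)sc3n2)c1`, 3000 nM
compound 2, `Nc1cccc(-c2cn3nc(-c4ccc(Cl)cc4)sc3n2)c1`, 160000 nM
compound 3, `Nc1cccc(-c2cn3nc(-c4ccccc4)sc3n2)c1`, 26000 nM

In a functional assay on HeLa cells (Homo sapiens) for inhibition, read by cell counting, with a stated time of 4 days (on this read-out higher numbers stand for weaker inhibition and lower numbers for stronger inhibition), compound 1 gives the lowest number of the three; compound 3 gives 26000 nM and compound 2 gives 160000 nM. The two measured steps are a 53-fold higher number from compound 1 to compound 2 (1.73 log units; beyond the scatter) and a 6.2-fold lower number from compound 2 to compound 3 (0.79 log units; beyond the scatter).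

Compound 4, `C=C(Br)C(=O)Nc1cccc(-c2cn3nc(-c4ccc(OC)cc4)sc3n2)c1`, differs from compound 1 in one place: methoxy in place of chloro on an aromatic carbon. For the measured compounds named here, no measured step exchanges chloro for methoxy. Going by the values given here, the only step touching this position is the removal of chloro in compound 2 to compound 3, a 6.2-fold lower number from compound 2 to compound 3 (0.79 log units; beyond the scatter), which is modest. A step of similar or smaller size toward a lower number is therefore expected, a 1.7-fold lower number from compound 1 to compound 4 (0.22 log units; within the scatter). Compound 4 is estimated at 1800 nM, expected range 500 nM to 6000 nM.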

Compound 4, half-maximal inhibitory concentration: 2300 nM
The estimate for compound 4 lay 1.3-fold (0.11 log units) below the measured number, within the range that was stated.
By their numbers in this assay, from the lowest: compounds 4 and 1 (each within the scatter of the next); then compound 3; then compound 2.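

In this assay, a 1.3-fold lower number from compound 1 to compound 4 (0.12 log units; within the scatter), so with the (1-bromoethenyl)carbonyl group on the nitrogen, 4-chlorophenyl and 4-methoxyphenyl cannot be told apart. The earlier step at this position, a 6.2-fold lower number from compound 2 to compound 3 (0.79 log units; beyond the scatter), removed chloro without that group present and showed that the position can matter; this exchange shows that chloro is not uniquely required when the group is present. No measured evidence accounts for this result.

Open, from the compounds shown here alone, is whether a carboxylic acid or dimethylamino group at this position would stay level with methoxy and chloro. Also open, going by these compounds, is how methoxy reads without the (1-bromoethenyl)carbonyl group.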